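The compounds below may be only part of what the source reports. "The series", "measured", "known", "first", "only" and "open" are said of these compounds alone.

In an ADME assay on HEK293 cells (Homo sapiens) for cytotoxicity, read by resazurin assay, with a stated time of 72 h (a higher number here means that more compound is tolerated, a lower number that less compound is tolerated), three compounds have been measured
- Compound 1 `O=C(O)c1ccc(CCOc2c(F)ccc3nc(C(=O)NCC4CCCCC4)[nH]c(=O)c23)cc1` gives > 20000 nM (a limit)
- Compound 2 `Cc1cc(CNC(=O)c2nc3ccc(F)c(OCCc4ccc(C(=O)O)cc4)c3c(=O)[nH]2)ccc1F` gives > 20000 nM (a limit)
- Compound 3 `CCc1cccc(CNC(=O)c2nc3ccc(F)c(OCCc4ccc(C(=O)O)cc4)c3c(=O)[nH]2)c1` gives > 20000 nM (a limit)

Compound 3 therefore has no exact number, only a limit (> 20000 nM). The same is true of all three compounds (the limit of > 20000 nM in this assay, at which 3 of the 3 values shown sit).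

Compound 4 `CCc1cccc(NC(=O)c2nc3ccc(F)c(OCCc4ccc(C(=O)O)cc4)c3c(=O)[nH]2)c1` has 3-ethylphenyl in place of 3-ethylbenzyl on an amide-type nitrogen. Among the measured compounds shown here, two measured steps bear on this change, as both end at compound 3 and alter the group on the same amide side: a step that the two limits leave unreadable from compound 1 to compound 3 and a step that the two limits leave unreadable from compound 2 to compound 3 are the two. The third step tells the same story (a step that the two limits leave unreadable from compound 1 to compound 2). None of them has a readable size, and none is the same change as the one made here, so no size or direction can be carried over.

No step beyond the usual scatter is expected, and the estimated step is small (a number no higher from compound 3 to compound 4 (the limit leaves the size open)). Compound 4 is expected to give about 20000 nM (estimated range 8000 nM to 40000 nM), most likely reported again as a limit.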

Compound 4, half-maximal cytotoxic concentration: > 20000 nM
Compound 4 gave a limit, no number; the forecaster's own chance of this, stated with the estimate: 80%; the middle value sits exactly at the limit.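

In this assay compound 4 gives > 20000 nM, which is a limit and not a number. Among the compounds shown here, no step among compound 1, compound 2, compound 3 and compound 4 can be read, since all four share one limit: the limit of > 20000 nM in this assay, at which 4 of the 4 values shown sit. Still open, on these data alone, is whether any of these amide-side changes, including 3-ethylphenyl for 3-ethylbenzyl, alters how much compound the cells tolerate.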